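Swapping methyl for 4-hydroxyphenyl on the anilino chain

The source may hold more compounds than are shown below. What is called first, only, known or untested is meant among the compounds shown, and "the series" means these compounds.

Swapping methyl for 4-hydroxyphenyl on a saturated chain carbon bound to a nitrogen on an aromatic ring

Three compounds share one core. Compound 1 `CC(=O)Nc1ccc(NC(=O)c2cc(Cl)ccc2O)c(Cl)c1` gives "not determined" (no result reported) in an ADME assay on A549 cells (Homo sapiens) for cytotoxicity, read by resazurin assay, with a stated time of 48 h (on this read-out higher numbers stand for lower toxicity in this test and lower numbers for higher toxicity in this test), so no result is reported for it. Compound 2 `CCNc1ccc(NC(=O)c2cc(Cl)ccc2O)c(Cl)c1` gives 30200 nM in this assay, the highest of the two numbers available, while compound 3 `O=C(Nc1ccc(NCC2CCCC2)cc1Cl)c1cc(Cl)ccc1O` gives 21500 nM in this assay. Among the compounds with values here, the one measured step, a 1.4-fold lower number from compound 2 to compound 3 (0.15 log units; within the scatter), is within the scatter, and its change is cyclopentyl in place of methyl on a saturated chain carbon bound to a nitrogen on an aromatic ring.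

Compound 4 `O=C(Nc1ccc(NCc2ccc(O)cc2)cc1Cl)c1cc(Cl)ccc1O` is not yet measured. It differs from compound 2 as follows: 4-hydroxyphenyl in place of methyl on a saturated chain carbon bound to a nitrogen on an aromatic ring. Within the data shown here, the only evidence that bears on it is the step from compound 2 to compound 3, which was within the scatter. Nothing on hand argues for a shift beyond the scatter in either direction. Compound 4 is therefore expected to give about 25000 nM in this assay, with a range of 10000 nM to 60000 nM, meaning an expected step of a 1.2-fold lower number from compound 2 to compound 4 (0.08 log units; within the scatter).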

Compound 4, half-maximal cytotoxic concentration: 116000 nM
Compound 4: middle estimate off by 4.6-fold (0.67 log units), on the low side; measured number outside the range, above it.
By their numbers in this assay, from the lowest: compounds 3 and 2 (each within the scatter of the next); then compound 4.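

In this assay this place on the chain proves able to move the number beyond the scatter, which cyclopentyl in compound 3 did not do. Putting 4-hydroxyphenyl in place of methyl gives a 3.8-fold higher number from compound 2 to compound 4 (0.58 log units; beyond the scatter) and putting it in place of cyclopentyl gives a 5.4-fold higher number from compound 3 to compound 4 (0.73 log units; beyond the scatter) on this read-out, so both changes point to lower toxicity in this test. No measurement on hand accounts for this rise.

The compounds shown leave open whether the aromatic ring or its hydroxyl carries the step, and a plain phenyl or a 4-methoxyphenyl at this place would separate the two. They also leave open how an amine or a carboxylic acid on the same chain would read in this assay here.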